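The source may report more compounds than this note shows. Statements on the series, on what has been measured and on what is new or still open speak of the compounds shown alone.

In a physicochemical assay for lipophilicity, read by HPLC, at pH 7.4 (a lower number here means a more polar compound, a higher number a more lipophilic compound), compound 2 `O=C(O)CCn1c(=O)oc2cc(OCc3ccccc3)c(Cl)cc21` gives 2.71, which places it second highest of the three values, close to compound 3 `C[C@@H](Oc1cc2onc(CCC(=O)O)c2cc1Cl)c1ccc(Cl)cn1` at 2.91 and to compound 1 `C[C@@H](Oc1cc2onc(CCC(=O)O)c2cc1Cl)c1ccc(F)cn1` at 2.47; both gaps lie within the scatter. Among the compounds with values here, the one measured step, a number 0.44 log units higher from compound 1 to compound 3 (beyond the scatter), concerns a halogen swap and so does not bear on the change to compound 4 `C[C@@H](Oc1cc2oc(=O)n(CCC(=O)O)c2cc1Cl)c1cccnn1`. That change is a group of 8 heavy atoms (6 carbon, 2 nitrogen; one six-membered aromatic ring with 2 hetero atoms) in place of a group of 7 heavy atoms (7 carbon; one six-membered aromatic ring of carbon only), on an oxygen on an aromatic ring. Within the data shown here, the entering group brings two hydrogen-bond acceptors where the leaving group had none, and no measured step mirrors such an exchange. Compound 4 is therefore expected to sit clearly lower, at an estimated 1.2 with a range from 0.6 to 1.8, a step of a number 1.51 log units lower from compound 2 to compound 4 (beyond the scatter) that is expected to exceed the scatter.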

Compound 4, distribution coefficient: 0.83
Estimate against measurement, compound 4: 0.37 log units above; the measured number falls inside the stated range.
By their numbers in this assay, from the lowest: compound 4; then compounds 1, 2 and 3 (each within the scatter of the next, the first and the last beyond it).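

Replacing benzyl on this oxygen on an aromatic ring with the group of 8 heavy atoms, which has a six-membered aromatic ring with 2 hetero atoms, gives in this assay a large step, a number 1.88 log units lower from compound 2 to compound 4 (beyond the scatter), whereas the halogen swap gave only a modest one, a number 0.44 log units higher from compound 1 to compound 3 (beyond the scatter). The earlier compounds shown here showed no change at this place. Nothing at hand accounts for the size of this step. From the compounds shown here alone, the ring with 2 hetero atoms and the defined stereocentre enter together, so their separate shares remain open. Going by these compounds, how an amine at this place would read in this assay also remains open.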